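Capping a Ring Amine: From Compound 1 to Compound 4

This account rests on a few compounds, and the source may have more. Where it says the series, first, only, none or still open, it means among the compounds named here.

Three compounds share a core and were tested in a functional assay on C-33-A cells (Homo sapiens) for antiproliferative activity, read by MTT assay; a higher number here means a weaker inhibitor, a lower number a stronger inhibitor. Compound 1, with the structure `c1ccc2c(c1)ccn2-c1nc(N2CCNCC2)nc2ccccc12`, gives 8.2 ug/mL and stands as the lowest of the three numbers. Compound 2, `CN1CCN(c2nc(-c3cn(C)c4ccccc34)c3ccccc3n2)CC1`, gives 50 ug/mL, and compound 3, `COc1ccc(-c2nc(N3CCN(C)CC3)nc3ccccc23)c(OC)c1`, gives 50 ug/mL; both of these gaps to compound 1 lie beyond the usual scatter, so compound 1 is the strongest inhibitor among the measured three.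

Compound 4, `c1ccc(N2CCN(c3nc(-n4ccc5ccccc54)c4ccccc4n3)CC2)nc1`, has not yet been measured. It differs from compound 1 in one place: pyridin-2-yl in place of hydrogen on an amine nitrogen in a ring. Within the data shown here, no pair of measured compounds differs by this kind of change, so nothing here shows how such a replacement moves the number.

Among the measured compounds shown here, with no comparable step to lean on, a change within the scatter, or a modest weakening, is expected. In this assay compound 4 is estimated at 12 ug/mL, in a range from 3 ug/mL to 45 ug/mL, which would mean an expected step of a 1.5-fold higher number from compound 1 to compound 4 (0.17 log units; within the scatter).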

Compound 4, half-maximal inhibitory concentration: 50 ug/mL
For compound 4 the middle estimate is 4.2-fold (0.62 log units) below the measured one; the whole stated range lies below it.
By their numbers in this assay, from the lowest: compound 1; then compounds 2, 3 and 4 (each within the scatter of the next).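

In this assay, putting pyridin-2-yl in place of hydrogen on the amine nitrogen in the six-membered ring gives a 6.1-fold higher number from compound 1 to compound 4 (0.79 log units; beyond the scatter). Among these compounds, this is the first direct reading of this position, since the earlier compounds differed from one another in more than one place: with the rest of compound 1 held fixed, this replacement on the nitrogen weakens the inhibitor by more than the usual scatter. Nothing measured here explains why the number moves.

One replacement cannot show whether any group on this nitrogen weakens the inhibitor or whether the loss belongs to pyridin-2-yl alone. An acetyl group or a benzyl group on the same nitrogen, with the rest of compound 1 unchanged, would help separate those two readings.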